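This account rests on a few compounds, and the source may have more. Where it says the series, first, only, none or still open, it means among the compounds named here.

Two compounds of this series share one core and differ only in the aryl group attached to an amide-type nitrogen. Compound 1 `COc1cc(Cl)cc(-c2nn(-c3cccc(NC(=O)Nc4ccc(Cl)c(Cl)c4)c3)cc2-c2ccncc2)c1` gives 102% in a functional assay on IGROV-1 cells (Homo sapiens) for inhibition, read by sulforhodamine B assay, with a stated time of 48 h, tested at 1 uM; on this read-out lower numbers stand for a stronger effect and higher numbers for a weaker effect at the one concentration tested. Compound 2 `COc1cc(Cl)cc(-c2nn(-c3cccc(NC(=O)Nc4cccc(C(F)(F)F)c4)c3)cc2-c2ccncc2)c1` gives 85% in this assay. Within the data shown here, the single measured step, a number 17 percentage points lower from compound 1 to compound 2 (beyond the scatter), is the only comparison available, and on it compound 2 stands lowest of the two numbers, with compound 1 the nearest and higher.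

Compound 3 `COc1cc(Cl)cc(-c2nn(-c3cccc(NC(=O)c4cccc(C(F)(F)F)c4)c3)cc2-c2ccncc2)c1` is not yet measured. It differs from compound 2 by 3-(trifluoromethyl)phenyl in place of (3-(trifluoromethyl)phenyl)amino on a carbonyl carbon. Among the measured compounds shown here, the measured step from compound 1 to compound 2 changed the aryl group on the amide-type nitrogen, not the carbonyl carbon, so no measured step bears directly on the change from compound 2 to compound 3. The two known values span a modest range at the upper end of the scale, so compound 3 is expected to fall in a similar region, with a step of a number 7 percentage points higher from compound 2 to compound 3 (within the scatter) that is not expected to exceed the scatter. Compound 3 is therefore estimated at 92%, within 75% to 108%.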

Compound 3, a percentage reported as activity, at one concentration (the size of the read-out at that concentration, not a potency): 94%
Estimate against measurement, compound 3: 2 percentage points below, and the stated range covers the measured number.
By their numbers in this assay, from the lowest: compounds 2, 3 and 1 (each within the scatter of the next, the first and the last beyond it).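

In this assay putting 3-(trifluoromethyl)phenyl in place of (3-(trifluoromethyl)phenyl)amino on the carbonyl carbon gives a number 9 percentage points higher from compound 2 to compound 3 (within the scatter) and so shows that losing this nitrogen, with its hydrogen-bond donor, does not move the read-out beyond the scatter at the one concentration tested. The change from (3,4-dichlorophenyl)amino to 3-(trifluoromethyl)phenyl at the same place gives a number 8 percentage points lower from compound 1 to compound 3 (within the scatter) and leaves compound 3 separable from neither of the other two, even though the earlier step, a number 17 percentage points lower from compound 1 to compound 2 (beyond the scatter), lies beyond the scatter. Nothing measured here beyond these numbers bears on why the read-out behaves this way.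

The compounds shown leave open whether a different group on this carbonyl carbon, such as a piperidine, a benzyl group or a longer chain ending in the same aryl ring, would give a clearer effect on these cells. They also leave open how the 3,4-dichlorophenyl group would read when attached directly to the carbonyl carbon, and how any of these compounds would behave at other concentrations.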